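The source may report more compounds than this note shows. Statements on the series, on what has been measured and on what is new or still open speak of the compounds shown alone.

Compound 1 `Cc1ccccc1NNC(=O)c1ccc(NS(=O)(=O)c2cnc(O)nc2O)cc1` gives > 20000 nM in a functional assay on OVCAR-3 cells (Homo sapiens) for antiproliferative activity, read by MTT assay, with a stated time of 24 h; on this read-out higher numbers stand for weaker inhibition and lower numbers for stronger inhibition.
Compound 2 `Cc1ccccc1NNC(=O)c1cccc(NS(=O)(=O)c2cnc(O)nc2O)c1` gives > 20000 nM in this assay.
Compound 3 `Cc1ccccc1NNC(=O)c1ccccc1NS(=O)(=O)c1cnc(O)nc1O` gives > 20000 nM in this assay.

Each of these three values is a limit of the assay rather than a measured number. Compound 2 therefore stands at the same limit as its two companions, and no order among the three can be drawn: all of them sit at the limit of > 20000 nM in this assay, at which 3 of the 3 values shown sit, which is what the assay reports when no half-maximal inhibitory concentration is reached in the tested range.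

Compound 4 `O=C(NNC(=O)c1cccc(NS(=O)(=O)c2cnc(O)nc2O)c1)c1cccc(Cl)c1` is not yet measured. It differs from compound 2 in one place: (3-chlorophenyl)carbonyl in place of 2-methylphenyl on an amine nitrogen. Cut one bond further out, the same difference reads (2-methylphenyl)amino to ((3-chlorophenyl)carbonyl)amino; the rest of the shared core is untouched.

Within the data shown here, no step between two measured compounds exists here, so the size of this change cannot be read from any measured pair. Starting from a limit, the expected step of a number no higher from compound 2 to compound 4 (the limit leaves the size open) is none beyond the usual scatter. Compound 4 is therefore estimated to give about 20000 nM in this assay, within a range of 5000 nM to 60000 nM, with a real chance that only a limit is reported again.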

Compound 4, half-maximal inhibitory concentration: 13500 nM
For compound 4 the middle estimate is 1.5-fold (0.17 log units) above the measured one; the measured number falls inside the stated range.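

Placing (3-chlorophenyl)carbonyl instead of 2-methylphenyl on this amine nitrogen gives the only value shown in this assay that is a real number rather than a limit, so the assay can report a half-maximal inhibitory concentration for this family of compounds. On these data alone, the change reads as an at least 1.4-fold lower number from compound 2 to compound 4 (0.17 log units; that floor lies within the scatter), but this is only a floor, since one end of the step is a limit: the true size stays open, and the step as printed does not establish a real separation between the two compounds. The other compounds offer no number for comparison: the limit of > 20000 nM in this assay, at which 3 of the 4 values shown sit.

The change swaps a methyl-bearing ring joined directly to the nitrogen for a chlorine-bearing ring joined through a carbonyl, so the compounds shown cannot say whether the carbonyl or the chlorine matters, which a plain benzoyl group or an acetyl group on the same nitrogen could help separate. They also leave open whether (3-chlorophenyl)carbonyl would give a measurable number on the frameworks of compound 1 and compound 3, where the sulfonamide-bearing ring is substituted differently.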